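This account rests on a few compounds, and the source may have more. Where it says the series, first, only, none or still open, it means among the compounds named here.

Measured so far:
- compound 1 `O=C(NCc1cc(-c2ccc(C(F)(F)F)nc2)ncn1)[C@@H]1CCN1S(=O)(=O)c1ccc(F)cc1`: 1500 nM
- compound 2 `O=C(NCc1cc(-c2ccc(C(F)(F)F)nc2)ncn1)[C@@H]1CCCN1S(=O)(=O)c1ccc(F)cc1`: 154 nM

In an assay on HEK293 cells for inhibition of transient receptor potential cation channel subfamily A member 1 (Homo sapiens), read by FLIPR and calcium flux, with a stated time of 20 min (on this read-out higher numbers stand for weaker inhibition and lower numbers for stronger inhibition), compound 2 gives 154 nM and compound 1 gives 1500 nM. Among the measured compounds shown here, compound 2 thus stands at the lowest of the two numbers, with compound 1 as its only neighbour at a higher number, a gap beyond the scatter; the two differ in the size of the saturated ring that carries the (4-fluorophenyl)sulfonyl group, but no single-point step between them is recorded, so only the two values themselves can be read.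

Compound 3 `C[C@H]1CC[C@@H](C(=O)NCc2cc(-c3ccc(C(F)(F)F)nc3)ncn2)N1S(=O)(=O)c1ccc(F)cc1` carries the change (methyl in place of hydrogen on a saturated ring carbon), a methyl in place of hydrogen on a saturated ring carbon. For the measured compounds named here, no measured pair shows the effect of such a methyl, so nothing fixes the direction. A step of a 1.0-fold higher number from compound 2 to compound 3 (0.02 log units; within the scatter) is expected, that is, no shift clearly beyond the scatter. Compound 3 is estimated at 160 nM, within 50 nM to 500 nM.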

Compound 3, half-maximal inhibitory concentration in the transient receptor potential cation channel subfamily A member 1 assay: 13 nM
The estimate for compound 3 lay 12-fold (1.09 log units) above the measured number, and the stated range ends above it.
By their numbers in the transient receptor potential cation channel subfamily A member 1 assay, from the lowest: compound 3; then compound 2; then compound 1.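

Among the compounds shown here, in the transient receptor potential cation channel subfamily A member 1 assay compound 2 stands at 154 nM and compound 3 at 13 nM with a methyl in place of hydrogen on a saturated ring carbon, next to the ring atom that bears a (4-fluorophenyl)sulfonyl group, which gives a large step (a 12-fold lower number from compound 2 to compound 3 (1.07 log units; beyond the scatter)), so this ring carbon of compound 2 is not indifferent to substitution, which the earlier compounds could not show. In a physicochemical assay for lipophilicity, at pH 7.4 (on this read-out higher numbers stand for higher lipophilicity and lower numbers for lower lipophilicity), compound 2 stands at 2.7 and compound 3 at 2.9 with the same change, a much less telling result (a number 0.20 log units higher from compound 2 to compound 3 (within the scatter)), so the distribution coefficient does not separate the two compounds. Nothing measured here accounts for the step in potency.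

Open, from the compounds shown here alone, is whether an ethyl or a hydroxymethyl at this carbon, or the methyl in the opposite stereochemistry, would keep the step. Also open, going by these compounds, is whether the same methyl would act alike on the ring of compound 1.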